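Series notes: nitrogen substituent on the shared core

This account rests on a few compounds, and the source may have more. Where it says the series, first, only, none or still open, it means among the compounds named here.

Compound 1 `COC(=O)C(C)n1n[n+]([O-])c2cc(C)c(C)cc21` in a functional assay on KB cells (Homo sapiens) for inhibition, read by colorimetric assay, with a stated time of 72 h (a higher number here means that more compound is needed for the effect, a lower number that less compound is needed), gives > 100 ug/mL, a limit of the assay rather than a number.
Compound 2 `Cc1cc2c(cc1C)[n+]([O-])nn2C` in this assay gives > 100 ug/mL, again a limit.
Compound 3 `Cc1cc2c(cc1C)[n+]([O-])nn2Cc1ccccc1` in this assay gives > 100 ug/mL, also a limit.

Compound 3 therefore stands at the limit of > 100 ug/mL in this assay, at which 3 of the 3 values shown sit, and is not separated by any number from the other two. The step that the two limits leave unreadable from compound 1 to compound 2 and the step that the two limits leave unreadable from compound 2 to compound 3 are both unreadable, so the change at the aromatic nitrogen has so far shown nothing readable.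

Compound 4 `COC(=O)Cn1n[n+]([O-])c2cc(C)c(C)cc21` carries methoxycarbonyl in place of phenyl on a saturated chain carbon bound to an aromatic nitrogen. For the measured compounds named here, no measured step bears readably on this change, so no direction can be expected from the steps; only the common limit of > 100 ug/mL in this assay, at which 3 of the 3 values shown sit, speaks. A step that the limit leaves unreadable from compound 3 to compound 4 is estimated. For compound 4 a value of 150 ug/mL is expected, within 30 ug/mL to 1000 ug/mL, most likely again reported only as a limit.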

Compound 4, concentration for half-maximal effect: > 100 ug/mL
Compound 4: no number, only a limit; the forecaster's own chance of this, stated with the estimate: 80%; the middle value does not contradict the limit.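

Compound 4 also gives only a limit, so its steps to compound 1, compound 2 and compound 3 cannot be read: the limit of > 100 ug/mL in this assay, at which 4 of the 4 values shown sit. The compounds shown leave open whether any nitrogen substituent on the shared core reaches a measurable value in this assay.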